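Moving the Fluorine Around the Phenyl Group

The source may hold more compounds than are shown below. What is called first, only, known or untested is meant among the compounds shown, and "the series" means these compounds.

Within the data shown here, compound 3 `O=c1[nH]cc(S(=O)(=O)Nc2cccc(-c3cn(-c4ccccc4F)nn3)c2)c(=O)[nH]1` stands second highest of the three numbers measured so far in a functional assay on SGC-7901 cells (Homo sapiens) for antiproliferative activity, read by MTT assay, with a stated time of 24 h; a lower number here means a stronger inhibitor, a higher number a weaker inhibitor; compound 3 gives 16000 nM. Its nearest neighbour is compound 1 `O=c1[nH]cc(S(=O)(=O)Nc2cccc(-c3cn(-c4ccccc4)nn3)c2)c(=O)[nH]1`, which gives 17200 nM, and the furthest is compound 2 `Cc1ccc(-n2cc(-c3cccc(NS(=O)(=O)c4c[nH]c(=O)[nH]c4=O)c3)nn2)cc1`, which gives 9430 nM. Compound 4 `O=c1[nH]cc(S(=O)(=O)Nc2cccc(-c3cn(-c4cccc(F)c4)nn3)c2)c(=O)[nH]1` differs from compound 3 by 3-fluorophenyl in place of 2-fluorophenyl on an aromatic nitrogen. Among the measured compounds shown here, three measured steps bear on this change. Adding a single fluorine gave a 1.1-fold lower number from compound 1 to compound 3 (0.03 log units; within the scatter). Methyl in place of hydrogen on an aromatic carbon gave a 1.8-fold lower number from compound 1 to compound 2 (0.26 log units; within the scatter). Exchanging the whole group on the aromatic nitrogen gave a 1.7-fold higher number from compound 2 to compound 3 (0.23 log units; within the scatter). Every change made so far on the aromatic nitrogen has left the number within the scatter, so the step expected here is a 1.1-fold lower number from compound 3 to compound 4 (0.03 log units; within the scatter), with no movement beyond the scatter in either direction. Compound 4 is therefore estimated at 15000 nM in this assay, with a range from 7000 nM to 35000 nM.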

Compound 4, half-maximal inhibitory concentration: > 20000 nM
Compound 4 ended at the assay's limit (the forecaster's own chance of this, stated with the estimate: 5%); middle value at least 1.3-fold (0.12 log units) away from the limit.
By their numbers in this assay, from the lowest: compounds 2, 3 and 1 (each within the scatter of the next). At a limit, above all of these: compound 4.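

In this assay compound 4 gives > 20000 nM, which is a limit of the assay and not a number, and it is the only such value among the compounds shown: the limit of > 20000 nM in this assay, at which 1 of the 4 values shown sits. Exchanging 2-fluorophenyl for 3-fluorophenyl gives an at least 1.2-fold higher number from compound 3 to compound 4 (0.09 log units; that floor lies within the scatter), and placing the fluorine on the plain phenyl group gives an at least 1.1-fold higher number from compound 1 to compound 4 (0.06 log units; that floor lies within the scatter), so neither floor shows a real loss. Against the 4-methylphenyl group, however, the step is an at least 2.1-fold higher number from compound 2 to compound 4 (0.32 log units; beyond the scatter), the first change on this aromatic nitrogen to pass beyond the scatter.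

As far as these compounds go, with compound 4 at a limit, how far moving the fluorine truly shifts the number stays open. Also open, from the compounds shown here alone, is whether a methoxy group or an amine in place of the fluorine on this phenyl group would move the number beyond the scatter.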